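The compounds below may be only part of what the source reports. "The series", "measured", "known", "first", "only" and "open" are said of these compounds alone.

Measured in a functional assay on K562 cells (Homo sapiens) for antiproliferative activity, read by MTT assay, with a stated time of 72 h; on this read-out higher numbers stand for weaker inhibition and lower numbers for stronger inhibition:
- compound 1 `COc1cc(C(=O)c2sc3ccccc3c2-c2ccccc2)cc(OC)c1OC` gives 2100 nM on this read-out
- compound 2 `COc1ccccc1-c1c(C(=O)c2cc(OC)c(OC)c(OC)c2)sc2ccccc12` gives 3400 nM on this read-out

Compound 2 has only compound 1 to be compared with, and the two cannot be ranked: the gap between them (a 1.6-fold higher number from compound 1 to compound 2 (0.21 log units; within the scatter)) lies within the scatter. Compound 3 `COc1ccc(-c2c(C(=O)c3cc(OC)c(OC)c(OC)c3)sc3ccccc23)c(OC)c1` is compound 2 with one group added (methoxy in place of hydrogen on an aromatic carbon), turning 2-methoxyphenyl into 2,4-dimethoxyphenyl. Going by the values given here, the only measured step that bears on this is the one just given, the same kind of change, methoxy in place of hydrogen on an aromatic carbon, made at a different place. That single step stayed within the scatter, so no shift beyond the scatter, in either direction, is expected in this assay here. The expected step (a 1.1-fold lower number from compound 2 to compound 3 (0.05 log units; within the scatter)) is only an estimate. For compound 3 the estimate is 3000 nM (expected range 1200 nM to 7500 nM).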

Compound 3, half-maximal inhibitory concentration: 4100 nM
Estimate against measurement, compound 3: 1.4-fold (0.14 log units) below, within the range that was stated.
By their numbers in this assay, from the lowest: compounds 1, 2 and 3 (each within the scatter of the next).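

In this assay, adding a methoxy group to the ring that already carries one, meta to that methoxy and para to a large group, gives a 1.2-fold higher number from compound 2 to compound 3 (0.08 log units; within the scatter) and so shows no shift that can be told from the scatter. Taken together, the two methoxy groups of 2,4-dimethoxyphenyl in place of phenyl give a 2.0-fold higher number from compound 1 to compound 3 (0.29 log units; within the scatter) and this combined change also stays within the scatter. Nothing available here speaks to the reason for these small steps.

From the compounds shown here alone, it remains open whether a different group at this position, such as an amine, a carboxylic acid or a longer chain, would move the number beyond the scatter. The compounds shown differ only on this one ring, so the effect of changes elsewhere on the shared core also remains open.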